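The source may hold more compounds than are shown below. What is called first, only, known or untested is meant among the compounds shown, and "the series" means these compounds.

Compound 1 `O=S(=O)(Nc1cccc2ccccc12)c1ccc2nc(-c3ccccc3)c(-c3ccccc3)nc2c1`: 100%
Compound 2 `O=C(O)c1ccccc1NS(=O)(=O)c1ccc2nc(-c3ccccc3)c(-c3ccccc3)nc2c1`: 83.6%

Both were tested in an ADME assay on the whole organism for pharmacokinetics, with Homo sapiens as the target; on this read-out lower numbers stand for lower oral bioavailability and higher numbers for higher oral bioavailability. Compound 2 holds the lower of the two numbers; compound 1 stands higher, as the step of a number 16.4 percentage points lower from compound 1 to compound 2 (beyond the scatter) shows, a modest fall that lies beyond the scatter. Compound 3 `O=S(=O)(Nc1ccc(O)cc1)c1ccc2nc(-c3ccccc3)c(-c3ccccc3)nc2c1` has not yet been measured. It differs from compound 2 at a single place: 4-hydroxyphenyl in place of 2-carboxyphenyl on a sulfonamide nitrogen. Among the compounds with values here, the only measured step that touches the same spot is the one from compound 1 to compound 2, in which the group on the sulfonamide nitrogen was exchanged. Compound 2 carries the 2-carboxyphenyl that arrived with that fall; compound 3 takes it away again, so a small rise back toward compound 1 is expected, though the data cannot fix its size. Compound 3 is estimated at 85% in this assay, with a range from 60% to 100%. The expected step is thus a number 1.4 percentage points higher from compound 2 to compound 3 (within the scatter).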

Compound 3, oral bioavailability: 93.9%
Estimate against measurement, compound 3: 8.9 percentage points below; the range from low to high includes it.
By their numbers in this assay, from the lowest: compound 2; then compounds 3 and 1 (each within the scatter of the next).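

In this assay, putting 4-hydroxyphenyl in place of 2-carboxyphenyl on the sulfonamide nitrogen gives a number 10.3 percentage points higher from compound 2 to compound 3 (beyond the scatter), so this position responds to a change between two single phenyl rings that each carry one substituent, and not only to the exchange of naphthalen-1-yl seen earlier. Exchanging naphthalen-1-yl for 4-hydroxyphenyl gives a number 6.1 percentage points lower from compound 1 to compound 3 (within the scatter), so the smaller ring with its hydroxyl group cannot be told apart from the larger ring system in this read-out. Nothing available explains either step.

Going by these compounds, it remains open whether the lower number of compound 2 belongs to the carboxylic acid itself or to the 2-carboxyphenyl group as a whole, since each step swaps the entire group at once. On these data alone, how an unsubstituted phenyl, or a phenyl carrying an amine, would stand on this nitrogen is also open.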